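The source may hold more compounds than are shown below. What is called first, only, known or untested is meant among the compounds shown, and "the series" means these compounds.

Three compounds have so far been run in a toxicity assay on HeLa cells (Homo sapiens) for cytotoxicity, read by MTT assay, with a stated time of 24 h; on this read-out lower numbers stand for stronger inhibition and higher numbers for weaker inhibition. Compound 1 `CCN(C)C(=S)SCC(O)Cn1c([N+](=O)[O-])cnc1C` gives 4150000 nM in this assay, and compound 3 `Cc1ncc([N+](=O)[O-])n1CC(O)CN1CCC(Cc2ccccc2)CC1` gives 1430000 nM in this assay. Compound 2 `Cc1ncc([N+](=O)[O-])n1CC(O)CN1CCN(c2ccccc2)CC1` returned no number at all in this assay but only > 5000000 nM. That reading is a limit of the assay (the limit of > 5000000 nM in this assay, at which 1 of the 3 values shown sits), so compound 2 cannot be placed against the other two with any confidence; all that is known is that it sits at the weak edge of what this assay reports.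

Compound 4 `Cc1ncc([N+](=O)[O-])n1CC(O)CN1CCN(c2ccco2)CC1` has not yet been measured and differs from compound 2 in one place: furan-2-yl in place of phenyl on an amine nitrogen in a ring. Among the measured compounds shown here, no measured pair among the three compounds differs in a single place, so no measured step points the way for this change. The expectation for compound 4 is therefore drawn from compound 2 alone, with a wide range around it. The author expects the step from compound 2 to compound 4 a number no higher from compound 2 to compound 4 (the limit leaves the size open) to be none beyond the scatter, and expects that this assay may again report only a limit. The estimate for compound 4 is 5000000 nM, with a range from 1500000 nM to 15000000 nM.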

Compound 4, half-maximal inhibitory concentration: 3520000 nM
Compound 4: middle estimate off by 1.4-fold (0.15 log units), on the high side; the measured number falls inside the stated range.
By their numbers in this assay, from the lowest: compound 3; then compounds 4 and 1 (each within the scatter of the next). At a limit, above all of these: compound 2.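

In this assay, among the compounds shown here, compound 4 gives 3520000 nM, the only number so far for a compound with an aromatic ring on this amine nitrogen of the six-membered ring with two nitrogens. For compound 2 the reading is a limit, > 5000000 nM. Furan-2-yl in place of phenyl therefore brings this position within the range that can be read as a number, with an at least 1.4-fold lower number from compound 2 to compound 4 (0.15 log units; that floor lies within the scatter), but the true size of the step stays unfixed and may be no more than the floor printed with it: the limit of > 5000000 nM in this assay, at which 1 of the 4 values shown sits.

The compounds shown do not separate the ring oxygen of furan-2-yl from the change from a six-membered to a five-membered aromatic ring; a thiophen-2-yl group on the same nitrogen would keep the five-membered ring without the oxygen, and a pyridin-2-yl group would keep the six-membered ring with a hetero atom. They also leave open how this assay would read a substituted aromatic ring at this place, such as a phenyl carrying a methoxy group or a carboxylic acid, which could also give compound 2's phenyl series a first real number.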